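The source may report more compounds than this note shows. Statements on the series, on what has been measured and on what is new or still open speak of the compounds shown alone.

Measured compounds:
compound 1, `CC(C)c1ccccc1OS(=O)(=O)c1cccc(NC(=O)CCCl)c1`, 8200 nM
compound 2, `CC(C)c1ccccc1OS(=O)(=O)c1ccc(NC(=O)C(C)(C)C)cc1`, 11000 nM
compound 3, `CC(C)(C)C(=O)Nc1ccc(S(=O)(=O)Oc2ccccc2I)cc1`, 2600 nM

In a functional assay on HT-1080 cells (Homo sapiens) for antiproliferative activity, read by sulforhodamine B assay, with a stated time of 48 h (a lower number here means a stronger inhibitor, a higher number a weaker inhibitor), compound 3 gives the lowest of the three numbers; compound 1 is nearest and compound 2 furthest, and both gaps lie beyond the scatter. For the measured compounds named here, the only measured step, a 4.2-fold lower number from compound 2 to compound 3 (0.63 log units; beyond the scatter), concerns a substituent on an aromatic carbon and leaves the amide untouched. Compound 4, `CCNC(=O)Nc1ccc(S(=O)(=O)Oc2ccccc2I)cc1`, comes next; the change is ethylamino in place of tert-butyl on a carbonyl carbon. Going by the values given here, no measured step bears on this part of the molecule, so there is no direct guide. The estimated step is a 1.2-fold higher number from compound 3 to compound 4 (0.06 log units; within the scatter), which is expected to stay within the scatter. Compound 4 is expected to give 3000 nM, with a range from 1000 nM to 9000 nM.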

Compound 4, half-maximal inhibitory concentration: 140 nM
The estimate for compound 4 lay 21-fold (1.33 log units) above the measured number; the measured number lies below the stated range.
By their numbers in this assay, from the lowest: compound 4; then compound 3; then compounds 1 and 2 (each within the scatter of the next).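

The carbonyl carbon proves to be a highly sensitive position in this assay: ethylamino in place of tert-butyl gives a 19-fold lower number from compound 3 to compound 4 (1.27 log units; beyond the scatter). For the compounds shown here, this change removes a purely carbon group and brings in a nitrogen with a hydrogen-bond donor, but the single step cannot separate the contribution of either feature. No available evidence explains the step.

From the compounds shown here alone, it remains open whether methylamino, propylamino or dimethylamino on this carbonyl carbon would give a comparable number. Also open, going by these compounds, is whether ethylamino would give a similar step with isopropyl in place of iodo on the aromatic carbon.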